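The source may report more compounds than this note shows. Statements on the series, on what has been measured and on what is new or still open speak of the compounds shown alone.

Measured in an ADME assay on microsomes from liver (Rattus norvegicus) for metabolic stability; on this read-out higher numbers stand for a more stable compound and lower numbers for a less stable compound:
- compound 1 `C/C(CN)=C(/F)CN(C[C@H]1Cc2ccccc2CN1)[C@H]1CCCc2cccnc21`: 72%
- compound 2 `C/C(CN)=C(\F)CN(C[C@H]1Cc2ccccc2CN1)[C@H]1CCCc2cccnc21`: 2%
- compound 3 `N[C@H]1CC[C@H](N(C[C@H]2Cc3ccccc3CN2)[C@H]2CCCc3cccnc32)CC1`: 71%

Compound 3 stands level with compound 1 at the top of this set, with a number 1 percentage points lower from compound 1 to compound 3 (within the scatter). Compound 2 lies far from both, with a number 69 percentage points higher from compound 2 to compound 3 (beyond the scatter).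

Next in the series is compound 4 `C/C(=C/CN)CN(C[C@H]1Cc2ccccc2CN1)[C@H]1CCCc2cccnc21`. The change is a group of 6 heavy atoms (5 carbon, 1 nitrogen; no ring) in place of a group of 7 heavy atoms (6 carbon, 1 nitrogen; one six-membered non-aromatic ring of carbon only), on an amine nitrogen. The six-membered ring of compound 3 is lost, and an open chain with a double bond enters, a kind of group also carried by compound 1 and compound 2.

The closest evidence is the pair of steps between those open chains and the ring group of compound 3, and they disagree. One is a number 1 percentage points lower from compound 1 to compound 3 (within the scatter), the other a number 69 percentage points higher from compound 2 to compound 3 (beyond the scatter). Open chains therefore span the whole measured range, and a number 70 percentage points lower from compound 1 to compound 2 (beyond the scatter) comes with the fact that compounds 1 and 2 differ only in the configuration as drawn.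

A step down from compound 3 is expected, though its size is poorly defined, and the estimated change is a number 36 percentage points lower from compound 3 to compound 4 (beyond the scatter). The estimate stays wide because of a number 70 percentage points lower from compound 1 to compound 2 (beyond the scatter). For compound 4 the expected value is 35%, with an estimated range from 5% to 75%.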

Compound 4, percent of the compound remaining: 2%
Compound 4: the middle estimate sits 33 percentage points above what was measured, and the stated range ends above it.
By their numbers in this assay, from the lowest: compounds 2 and 4 (each within the scatter of the next); then compounds 3 and 1 (each within the scatter of the next).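

Swapping 4-aminocyclohexyl on this amine nitrogen for the fluorine-free open chain removes nearly all of the read-out in this assay (a number 69 percentage points lower from compound 3 to compound 4 (beyond the scatter)), so an open chain on this nitrogen does not by itself keep the level of the ring group. Set against the two fluorinated chains, the new chain sides with only one: compound 4 matches compound 2 (no change at the digits printed from compound 2 to compound 4 (within the scatter)) and falls well short of compound 1 (a number 70 percentage points lower from compound 1 to compound 4 (beyond the scatter)). Of the three open chains, only compound 1 (72%) now stands level with compound 3 (71%), which makes it the exception in the series, and what separates it from the low pair is narrow in the case of compound 2: the fact that compounds 1 and 2 differ only in the configuration as drawn.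

Going by these compounds, whether compound 4's chain would recover the read-out of compound 1 with a chlorine or a methyl group in place of the fluorine remains open. Also open, on these data alone, is where a saturated chain such as 4-aminobutyl, with no double bond at all, would fall relative to compound 3 and compound 4.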